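Swapping Ethyl for Acetyl on a Ring Nitrogen

The source may report more compounds than this note shows. Statements on the series, on what has been measured and on what is new or still open speak of the compounds shown alone.

In a functional assay on NCI-H1581 cells (Homo sapiens) for antiproliferative activity, read by CCK-8 assay, with a stated time of 72 h (a higher number here means a weaker inhibitor, a lower number a stronger inhibitor), compound 1 `COc1cc(OC)c(Cl)c(-c2ccc3c(NC(=O)c4ccc(N5CCCCC5)cc4)n[nH]c3n2)c1Cl` gives 558 nM. Compound 2 `CCN1CCN(c2ccc(C(=O)Nc3n[nH]c4nc(-c5c(Cl)c(OC)cc(OC)c5Cl)ccc34)cc2)CC1` gives 0.7 nM, and compound 3 `COc1cc(OC)c(Cl)c(-c2ccc3c(NC(=O)c4ccc(N5CCN(C(C)C)CC5)cc4)n[nH]c3n2)c1Cl` gives 1.4 nM. Compound 2 and compound 3 therefore share the low end of this small series, far from compound 1.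

Compound 4 `COc1cc(OC)c(Cl)c(-c2ccc3c(NC(=O)c4ccc(N5CCN(C(C)=O)CC5)cc4)n[nH]c3n2)c1Cl` differs from compound 2 in one place, with acetyl in place of ethyl on an amine nitrogen in a ring. Two kinds of measured step bear on this change. Extending ethyl to isopropyl gave a 2.0-fold higher number from compound 2 to compound 3 (0.30 log units; within the scatter), so that small change in a saturated chain on this nitrogen made no clear difference. Exchanging piperidin-1-yl for 4-ethylpiperazin-1-yl gave an 800-fold lower number from compound 1 to compound 2 (2.90 log units; beyond the scatter), and the exchange for 4-isopropylpiperazin-1-yl gave a 400-fold lower number from compound 1 to compound 3 (2.60 log units; beyond the scatter), so this end of the molecule can matter greatly. Acetyl is not a saturated chain, and no measured compound carries it, so the guidance is loose. The expected step is a 21-fold higher number from compound 2 to compound 4 (1.33 log units; beyond the scatter), toward a weaker inhibitor. For compound 4 the estimated value is 15 nM, with an expected range of 2 nM to 120 nM.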

Compound 4, half-maximal inhibitory concentration: 43.3 nM
Beside the measured number, compound 4's estimate is 2.9-fold (0.46 log units) below it, within the range that was stated.
By their numbers in this assay, from the lowest: compounds 2 and 3 (each within the scatter of the next); then compound 4; then compound 1.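

For the compounds shown here, until this result, only saturated chains stood on this ring nitrogen, and swapping one for the other made no clear difference. In this assay, acetyl gives a 62-fold higher number from compound 2 to compound 4 (1.79 log units; beyond the scatter) and a 31-fold higher number from compound 3 to compound 4 (1.49 log units; beyond the scatter) as the two steps from those chains, so the group on this nitrogen can matter a great deal. With 4-acetylpiperazin-1-yl in place of piperidin-1-yl there is still a 13-fold lower number from compound 1 to compound 4 (1.11 log units; beyond the scatter) as a large step, so part of the gain over compound 1 remains with acetyl in place.

The compounds shown leave open whether the loss follows the carbonyl directly on the ring nitrogen or any oxygen-bearing group there. A 2-methoxyethyl chain, with its oxygen further out, or a methylsulfonyl group on the same nitrogen would separate these readings. Nothing available here explains the size of these steps.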